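A few compounds are considered here, and "the series" means these few. Any claim that something is new, unique, unknown or untested is made for them only; others in the source may bear on it.

Measured in a functional assay on HEL cells (Homo sapiens); a lower number here means that less compound is tolerated, a higher number that more compound is tolerated:
- compound 1 `CC(=O)NC1=CS(=O)(=O)O[C@@]12[C@@H](CO[Si](C)(C)C(C)(C)C)O[C@@H](n1cc(C)c(=O)n(C)c1=O)[C@@H]2O[Si](C)(C)C(C)(C)C`: > 200000 nM, which is a limit of the assay and not a number
- compound 2 `COC(=O)CNC1=CS(=O)(=O)O[C@@]12[C@@H](CO[Si](C)(C)C(C)(C)C)O[C@@H](n1cc(C)c(=O)n(C)c1=O)[C@@H]2O[Si](C)(C)C(C)(C)C`: 160000 nM
- compound 3 `COC(=O)CC(=O)NC1=CS(=O)(=O)O[C@@]12[C@@H](CO[Si](C)(C)C(C)(C)C)O[C@@H](n1cc(C)c(=O)n(C)c1=O)[C@@H]2O[Si](C)(C)C(C)(C)C`: 29000 nM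

The lowest number of the series belongs to compound 3. The nearest gap to it is a 5.5-fold lower number from compound 2 to compound 3 (0.74 log units; beyond the scatter). The other step that ends there is an at least 6.8-fold lower number from compound 1 to compound 3 (0.83 log units; beyond the scatter), and it is only a floor, set by the limit of > 200000 nM in this assay, at which 1 of the 3 values shown sits.

The next entry, compound 4 `Cc1cn([C@@H]2O[C@H](CO[Si](C)(C)C(C)(C)C)[C@@]3(OS(=O)(=O)C=C3NC(=O)NC(=O)c3ccccc3)[C@H]2O[Si](C)(C)C(C)(C)C)c(=O)n(C)c1=O`, carries the change benzamido in place of (methoxycarbonyl)methyl on a carbonyl carbon. Both steps named above bear on this change, since each alters the substituent on the same amine nitrogen and each gives a modest shift in this assay. Neither step tests benzamido, so they give a likely size but only a weak direction. Within the data shown here, the group that leaves is the one present in compound 3, which at 29000 nM sits at the low end of the series, so a small upward drift is the more likely outcome. The expected step is a 1.2-fold higher number from compound 3 to compound 4 (0.08 log units; within the scatter), and a modest move either way would not be surprising. For compound 4 the estimated value is 35000 nM, with an expected range of 10000 nM to 150000 nM.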

Compound 4, half-maximal cytotoxic concentration: >= 200000 nM
Compound 4 was reported as a limit; the forecaster's own chance of this, stated with the estimate: 15%; at least 5.7-fold (0.75 log units) between middle value and limit.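

In this assay the entry for compound 4 is a limit of the assay and not a number: the limit of >= 200000 nM in this assay, at which 1 of the 4 values shown sits.

Among these compounds, on the carbonyl carbon whose other neighbour is an amide-type nitrogen, benzamido in place of (methoxycarbonyl)methyl gives an at least 6.8-fold higher number from compound 3 to compound 4 (0.83 log units; beyond the scatter), so the low number seen with the (methoxycarbonyl)methyl group does not extend to every larger substituent at this place, and compound 3 remains the only compound here with a low number. The change of the whole substituent on the amine nitrogen to benzoylcarbamoyl reads an at least 1.2-fold higher number from compound 2 to compound 4 (0.09 log units; that floor lies within the scatter), while the step between the two compounds reported at limits cannot be read.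

As far as these compounds go, it remains open whether the lower number of compound 3 depends on the methoxycarbonyl group itself or on the chain that carries it, which a carboxylic acid, a primary amide or a longer chain ending in methoxycarbonyl on the same carbonyl carbon would separate. A phenyl group at that place would also separate the contribution of the aromatic ring from that of the added amide-type nitrogen.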